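A Primary Amine Becomes a Dimethylamine

This account rests on a few compounds, and the source may have more. Where it says the series, first, only, none or still open, it means among the compounds named here.

Of the compounds shown here, two sharing one core have been tested in an assay on HeLa cells for displacement of a labelled ligand from 5-hydroxytryptamine receptor 6 (Homo sapiens); a lower number here means a stronger inhibitor, a higher number a weaker inhibitor. Compound 1 `CN(C)CCn1cc(S(=O)(=O)c2ccccc2)c2cccnc21` gives 23 nM, and compound 2 `Cc1c(S(=O)(=O)c2ccccc2)c2cccnc2n1CCN` gives 4.2 nM, the lowest of the two numbers; the gap between compound 2 and compound 1 lies beyond the usual scatter of repeated measurements. Compound 3 `Cc1c(S(=O)(=O)c2ccccc2)c2cccnc2n1CCN(C)C` has not yet been measured in this assay. It differs from compound 2 in a single place: dimethylamino in place of amino on a saturated chain carbon, two bonds along the chain from an aromatic nitrogen. No measured pair isolates this change, so the expected size of its effect rests on general experience rather than on a shown step. The expected step is a 1.9-fold higher number from compound 2 to compound 3 (0.28 log units; within the scatter), a modest rise in the number that may or may not exceed the scatter. Compound 3 is therefore estimated at 8 nM, with a range from 2.5 nM to 25 nM.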

Compound 3, inhibition constant: 4.7 nM
For compound 3 the middle estimate is 1.7-fold (0.23 log units) above the measured one; measured number inside the range.
By their numbers in this assay, from the lowest: compounds 2 and 3 (each within the scatter of the next); then compound 1.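

In this assay, the step from amino to dimethylamino on this chain, a 1.1-fold higher number from compound 2 to compound 3 (0.05 log units; within the scatter), shows that the amino group with its one hydrogen-bond donor can give way to dimethylamino with none, with no difference beyond the scatter. A second change can now be read alone: with the 2-(dimethylamino)ethyl chain held the same, methyl in place of hydrogen on an aromatic carbon gives a 4.9-fold lower number from compound 1 to compound 3 (0.69 log units; beyond the scatter), whereas the earlier gap between the first two compounds mixed two changes. No measurement shown here bears on why either step has the size it has.

Going by these compounds, it remains open whether a bulkier amine such as pyrrolidine, or a longer chain such as 3-(dimethylamino)propyl, would fit this pattern. On these data alone, it is equally open whether ethyl or chlorine in place of the methyl would give a similar step.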